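The source may report more compounds than this note shows. Statements on the series, on what has been measured and on what is new or still open speak of the compounds shown alone.

Compound 1 `COc1ccc(C2=NN(c3ccccc3Cl)C(c3cccc(Cl)c3)C2)cc1OC`: "not determined" (no result reported)
Compound 2 `CC(C)(C)C1=NN(c2ccc(Cl)cc2)C(c2ccc(Cl)cc2)C1`: 17300 nM
Compound 3 `CC(C)(C)C1=NN(c2ccc(Br)cc2)C(c2ccc(Br)cc2)C1`: "not determined" (no result reported)

These three compounds were examined in a functional assay on HCT-116 cells (Homo sapiens) for cytotoxicity, read by a luciferase reporter and CellTiter-Glo, with a stated time of 72 h; a higher number here means a weaker inhibitor, a lower number a stronger inhibitor. Compound 3 has no number to stand on, and its entry reads "not determined" (no result reported). The same is true of compound 1, whose entry reads "not determined" (no result reported). Among the compounds with values here, only compound 2 gives a figure, at 17300 nM, so the set offers no measured step between two related compounds.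

The next compound to be tested is compound 4 `CC(C)(C)C1=NN(c2ccc(Br)cc2)C(c2ccc(Cl)cc2)C1`. It keeps the shared core of compound 3 and differs by a single substitution: chloro in place of bromo on an aromatic carbon. In words, chloro takes the place of bromo on an aromatic carbon, para to a large group, turning a 4-bromophenyl into a 4-chlorophenyl. One halogen atom is exchanged for another, and the count of rings, hydrogen-bond donors and hydrogen-bond acceptors stays the same.

Within the data shown here, with no measured step as a guide, this swap is expected to produce no change beyond the usual scatter in this assay, and no direction is favoured. The expectation for the level of activity leans on compound 2, the only measured reference, at 17300 nM. For compound 4 the estimated value is 15000 nM, with an expected range from 6000 nM to 40000 nM.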

Compound 4, half-maximal inhibitory concentration: 4300 nM
The estimate for compound 4 lay 3.5-fold (0.54 log units) above the measured number; measured number outside the range, below it.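

In this assay the measured change a 4.0-fold lower number from compound 2 to compound 4 (0.60 log units; beyond the scatter) gives a first size for a halogen exchange at this place, with bromo in place of chloro on an aromatic carbon, para to a large group. The step is modest but lies beyond the usual scatter, so in this one pair the choice of halogen at this place does matter, and the compound carrying bromo has the lower number, which marks the stronger inhibitor. Nothing measured here accounts for the step, which rests on a single pair of compounds.

On these data alone, the exchange from compound 3 to compound 4 cannot be read, since compound 3 has only the entry "not determined" (no result reported) and gives no number, so it remains open whether the same swap has a similar size in that setting. Also open, as far as these compounds go, is how other groups on this aromatic carbon, such as a nitrile, a trifluoromethyl or an amine, would compare with bromo and chloro, and whether plain hydrogen there would give a higher or a lower number.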